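This account rests on a few compounds, and the source may have more. Where it says the series, first, only, none or still open, it means among the compounds named here.

Measured in a functional assay on a cell-free system (Platelet, plasma, Oryctolagus cuniculus) for inhibition, with a stated time of 5 min; a higher number here means a weaker inhibitor, a lower number a stronger inhibitor:
- compound 1 `CCOC(=O)/C=C/c1cc(OC)c(OCc2nc(C)c(C)nc2C)c(OC)c1`: 631000 nM
- compound 2 `CCOC(=O)/C=C/c1cccc(OCc2nc(C)c(C)nc2C)c1`: 628000 nM

Among the measured compounds shown here, compound 1 and compound 2 lie within the scatter of each other, so compound 1 stands level with the only other measured member of the series. Both values sit in the same weak range.

The next entry is compound 3 `COc1cc(/C=C/C(=O)O)cc(OC)c1OCc1nc(C)c(C)nc1C`, which keeps the core of compound 1 and carries hydrogen in place of ethyl on an oxygen next to a carbonyl group, ethoxycarbonyl to carboxy: hydrogen in place of ethyl on an oxygen next to a carbonyl group. For the measured compounds named here, no measured pair covers this change, so the data give no direct guide to its size in this assay. A modest move toward a lower number is expected, with no change beyond the scatter also possible. The expected step is a 1.6-fold lower number from compound 1 to compound 3 (0.20 log units; within the scatter). Compound 3 is estimated at 400000 nM, with an expected range from 120000 nM to 1000000 nM.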

Compound 3, half-maximal inhibitory concentration: 182000 nM
Compound 3: middle estimate off by 2.2-fold (0.34 log units), on the high side; the range from low to high includes it.
By their numbers in this assay, from the lowest: compound 3; then compounds 2 and 1 (each within the scatter of the next).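

In this assay, hydrogen in place of ethyl on an oxygen next to a carbonyl group, ethoxycarbonyl to carboxy, gives a 3.5-fold lower number from compound 1 to compound 3 (0.54 log units; beyond the scatter). Among the compounds shown here, this is the first step beyond the scatter, and it shows that the number responds to a change at this position, though compound 3 still reads 182000 nM and so stays in the weak range. Nothing measured on hand accounts for the step.

The change rests on this single pair, so whether it carries over to the core of compound 2 is open. Also open, going by these compounds, is how a methyl ester, a longer-chain ester or a primary amide at this position would read against the carboxy and ethoxycarbonyl forms.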